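Methyl in Place of Trifluoromethyl on the Aryl Ring

The source may report more compounds than this note shows. Statements on the series, on what has been measured and on what is new or still open speak of the compounds shown alone.

Measured so far in an assay on membranes from brain for displacement of a labelled ligand from adenosine receptor A1 (Rattus norvegicus); a higher number here means a weaker inhibitor, a lower number a stronger inhibitor:
compound 1 `c1ccc(-c2nc3ccccn3c2NC2CCCCC2)cc1` gives > 100000 nM, a limit of the assay.
compound 2 `FC(F)(F)c1ccc(-c2nc3ccccn3c2NC2CCCCC2)cc1` gives > 100000 nM, also a limit of the assay.

Compound 2 stands at the limit in this assay, as does compound 1: the limit of > 100000 nM in this assay, at which 2 of the 2 values shown sit. Within the data shown here, the only measured step, a step that the two limits leave unreadable from compound 1 to compound 2, has no readable size. Compound 3 `Cc1ccc(-c2nc3ccccn3c2NC2CCCCC2)cc1` differs from compound 2 by methyl in place of trifluoromethyl on an aromatic carbon. Among the measured compounds shown here, the one step that bears on this change gives no size and no direction, so no movement beyond the scatter is expected. Compound 3 is therefore expected to sit at or near the limit in this assay, estimated at 100000 nM (range 30000 nM to 300000 nM), a step of a number no higher from compound 2 to compound 3 (the limit leaves the size open).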

Compound 3, inhibition constant: 2060 nM
Estimate against measurement, compound 3: 49-fold (1.69 log units) above; measured number outside the range, below it.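

In this assay the choice of group on this aromatic carbon, para to a large group, clearly matters: methyl gives a measurable number, with an at least 48-fold lower number from compound 2 to compound 3 (1.68 log units; beyond the scatter) and an at least 48-fold lower number from compound 1 to compound 3 (1.68 log units; beyond the scatter). The step between compound 1 and compound 2 cannot be read, and both compounds remain at a limit of the assay: the limit of > 100000 nM in this assay, at which 2 of the 3 values shown sit.

The compounds shown leave open whether ethyl, a longer chain, or methoxy at this place would lower the number further or lose the gain. They also leave open whether methyl would have the same effect elsewhere on the aryl ring.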